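Butyl for cyclopentyl on the shared core

This account rests on a few compounds, and the source may have more. Where it says the series, first, only, none or still open, it means among the compounds named here.

Compound 3 (`COc1cccc(OC)c1-c1c(C2CCCC2)[nH]c(=O)c(-c2nnc(Cc3ccc(Cl)cc3)o2)c1O`) gives 80% in an ADME assay on microsomes from liver (Homo sapiens) for metabolic stability, read by mass spectrometry, using NADPH, with a stated time of 10 min (a higher number here means that more of the compound is left, a lower number that less of the compound is left), and sits within the scatter of the two other measured compounds. Compound 1 (`COc1cccc(OC)c1-c1c(C2CC2)[nH]c(=O)c(-c2nnc(Cc3ccc(Cl)cc3)o2)c1O`) gives 88% in this read-out, and compound 2 (`CCCCc1[nH]c(=O)c(-c2nnc(Cc3ccccc3Cl)o2)c(O)c1-c1c(OC)cccc1OC`) gives 82% in the same read-out.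

The next compound to be read is compound 4 (`CCCCc1[nH]c(=O)c(-c2nnc(Cc3ccc(Cl)cc3)o2)c(O)c1-c1c(OC)cccc1OC`), which has no number yet. The change is butyl in place of cyclopentyl on an aromatic carbon and in words is butyl in place of cyclopentyl on an aromatic carbon. The group sits next to the ring nitrogen and ortho to a 2,6-dimethoxyphenyl group.

Among the compounds with values here, one measured step touches this same place: a number 8 percentage points lower from compound 1 to compound 3 (within the scatter) with cyclopentyl in place of cyclopropyl, and it stays within the scatter. Compound 2 already carries butyl, with the chlorine of its benzyl group placed differently, and it stands at 82% in the same range. Within the data shown here, no measured pair isolates butyl against a ring.

In this assay no step beyond the scatter is expected, and the estimated change is a number 2 percentage points higher from compound 3 to compound 4 (within the scatter) in size and direction. For compound 4 the estimated value is 82% with an expected range of 70% to 92% for repeat readings.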

Compound 4, percent of the compound remaining: 66%
The estimate for compound 4 lay 16 percentage points above the measured number, outside the stated range (below it).
By their numbers in this assay, from the lowest: compound 4; then compounds 3, 2 and 1 (each within the scatter of the next).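

In this assay, within the data shown here, butyl is the first group at this position to give a step beyond the scatter, both against cyclopentyl (a number 14 percentage points lower from compound 3 to compound 4 (beyond the scatter)) and against cyclopropyl (a number 22 percentage points lower from compound 1 to compound 4 (beyond the scatter)), whereas the two rings stay within the scatter of each other (a number 8 percentage points lower from compound 1 to compound 3 (within the scatter)); among the compounds carrying 4-chlorophenyl, the open chain therefore stands apart from both rings. The butyl reading also does not carry over from one benzyl pattern to the other, since moving the chlorine gives a step beyond the scatter (a number 16 percentage points lower from compound 2 to compound 4 (beyond the scatter)) with 4-chlorophenyl in place of 2-chlorophenyl, so the earlier butyl compound was no safe guide to this one. No measurement at hand bears on what lies behind the lower number at this position.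

Still open, on these data alone, is whether the split follows ring against open chain or belongs to butyl alone, which a propyl group, an isobutyl group or a longer chain such as hexyl at the same place would help to settle. Also open is whether the chlorine placement matters when a ring rather than butyl sits at this position, as no ring compound with 2-chlorophenyl stands among those shown.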